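Indazole amide to carbamate: a step in the ketone series

This account rests on a few compounds, and the source may have more. Where it says the series, first, only, none or still open, it means among the compounds named here.

Measured so far:
- compound 1, `O=C(COc1ccc(Oc2ccccc2)cc1)Cn1ncnn1`: 8 nM
- compound 2, `CC(=O)Nc1ccc2c(cnn2CC(=O)COc2ccc(Oc3ccccc3)cc2)c1`: 3900 nM

In an assay on microsomes from brain for inhibition of Fatty-acid amide hydrolase 1 (Rattus norvegicus), read by fluorescence and HPLC, with a stated time of 45 min (a higher number here means a weaker inhibitor, a lower number a stronger inhibitor), compound 1 gives 8 nM, and compound 2 gives 3900 nM. Compound 2 therefore stands at the weaker end of the two numbers seen, and the gap to compound 1 is well beyond the scatter of repeated measurements; the two compounds differ in more than one place, so the gap is noted only as what the two values show.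

Compound 3, `O=C(COc1ccc(Oc2ccccc2)cc1)Cn1ncc2cc(NC(=O)Oc3ccccc3)ccc21`, is not yet measured. It differs from compound 2 in one place: phenoxy in place of methyl on a carbonyl carbon. For the measured compounds named here, no step between measured compounds covers this change, so there is nothing to set its size. The change enlarges the substituent on the nitrogen of the core of compound 2 and adds one hydrogen-bond acceptor. The expectation is a modest gain, a step of a 2.6-fold lower number from compound 2 to compound 3 (0.41 log units; beyond the scatter), with a wide range reflecting the lack of any comparable measured pair. For compound 3 the estimate in this assay is 1500 nM, between 200 nM and 8000 nM.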

Compound 3, half-maximal inhibitory concentration: 2100 nM
Compound 3: the middle estimate sits 1.4-fold (0.15 log units) below what was measured, within the range that was stated.
By their numbers in this assay, from the lowest: compound 1; then compounds 3 and 2 (each within the scatter of the next).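

In this assay, for the compounds shown here, phenoxy in place of methyl on a carbonyl carbon gives a 1.9-fold lower number from compound 2 to compound 3 (0.27 log units; within the scatter) and so provides the first reading of a single change at this position. The substituent on the amide-type nitrogen can take on the seven heavy atoms, the six-membered aromatic ring and the added hydrogen-bond acceptor of phenoxy without a difference beyond the scatter, so acetamido and (phenoxycarbonyl)amino read alike in this series. Nothing measured alongside these values accounts for this result.

Still open, on these data alone, is whether a different kind of group on this carbonyl carbon, such as an amine, a carboxylic acid or a longer chain, would move the number beyond the scatter. As far as these compounds go, compound 1, which lacks this substituent and carries a different core, gives 8 nM and differs from compound 3 in more than one place, so which structural difference carries the gap between them also remains open.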